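This account rests on a few compounds, and the source may have more. Where it says the series, first, only, none or still open, it means among the compounds named here.

Measured so far:
compound 1 `Cc1cc(O)c(C2=NN(c3ccc(S(N)(=O)=O)cc3)C(c3ccccc3Cl)C2)cc1Cl`: 6390 nM
compound 2 `COc1ccc(C2CC(c3cc(Cl)c(C)cc3O)=NN2c2ccc(S(N)(=O)=O)cc2)cc1OC`: 38300 nM

Going by the values given here, in a functional assay on M14 cells (Homo sapiens) for antiproliferative activity, with a stated time of 48 h (on this read-out lower numbers stand for higher toxicity in this test and higher numbers for lower toxicity in this test), compound 2 stands highest of the two numbers; the only step known is a 6.0-fold higher number from compound 1 to compound 2 (0.78 log units; beyond the scatter). Compound 3 `COc1ccc(C2CC(c3cc(Cl)c(C)cc3O)=NN2c2ccc(S(N)(=O)=O)cc2)c(OC)c1OC` differs from compound 2 by methoxy in place of hydrogen on an aromatic carbon. Among the compounds with values here, no measured step adds a substituent to that ring; the single known step concerns a different exchange and does not bear on this change. Hence for compound 3 no step beyond the scatter is expected, with wide uncertainty. The estimate for compound 3 is 42000 nM (range 14000 nM to 130000 nM), which means an expected 1.1-fold higher number from compound 2 to compound 3 (0.04 log units; within the scatter).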

Compound 3, concentration lethal to 50% of the cells: 9080 nM
Compound 3: the middle estimate sits 4.6-fold (0.67 log units) above what was measured; the whole stated range lies above it.
By their numbers in this assay, from the lowest: compounds 1 and 3 (each within the scatter of the next); then compound 2.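

In this assay, methoxy in place of hydrogen on an aromatic carbon, ortho to a large group, gives a change beyond the scatter (a 4.2-fold lower number from compound 2 to compound 3 (0.63 log units; beyond the scatter)), so this position responds to substitution. With 2,3,4-trimethoxyphenyl in place of 2-chlorophenyl, the step stays within the scatter (a 1.4-fold higher number from compound 1 to compound 3 (0.15 log units; within the scatter)), so the two groups are not told apart in this test. Nothing at hand accounts for either step. As far as these compounds go, whether the response belongs to methoxy itself remains open. An amine or an ethoxy group at this position could test that, and a methoxy here without the other two methoxy groups would show whether the change depends on them.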